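A few compounds are considered here, and "the series" means these few. Any claim that something is new, unique, unknown or untested is made for them only; others in the source may bear on it.

Three compounds sharing one core, differing only in the group on the double-bonded chain, have been tested in a functional assay on MGC-803 cells (Homo sapiens) for antiproliferative activity, read by MTT assay, with a stated time of 72 h; on this read-out higher numbers stand for weaker inhibition and lower numbers for stronger inhibition. Compound 1 (`O=C(COc1ccc(C(=O)/C=C/c2ccc(Cl)cc2Cl)cc1)N[C@H]1CCOC1=O`) gives 26500 nM. Compound 2 (`O=C(COc1ccc(C(=O)/C=C/c2cccc([N+](=O)[O-])c2)cc1)N[C@H]1CCOC1=O`) gives > 64000 nM, which is a limit of the assay and not a number. Compound 3 (`O=C(COc1ccc(C(=O)/C=C/c2ccccc2Br)cc1)N[C@H]1CCOC1=O`), with a 2-bromophenyl group, gives 12200 nM, the lower of the two actual numbers, and the comparison shows a 2.2-fold lower number from compound 1 to compound 3 (0.34 log units; beyond the scatter).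

Compound 4 (`O=C(COc1ccc(C(=O)/C=C/c2ccc(Br)cc2)cc1)N[C@H]1CCOC1=O`) has the same atoms as compound 3, joined differently, with 4-bromophenyl in place of 2-bromophenyl on a double-bonded chain carbon bound to a double-bonded chain carbon. The counted difference reads (4-bromophenyl in place of 2-bromophenyl on a double-bonded chain carbon bound to a double-bonded chain carbon). Within the data shown here, no measured pair shows this exact change, so the evidence is indirect. The three measured steps all swap the group at this same place. They are a 2.2-fold lower number from compound 1 to compound 3 (0.34 log units; beyond the scatter), then an at least 2.4-fold higher number from compound 1 to compound 2 (0.38 log units; beyond the scatter), and finally an at least 5.2-fold lower number from compound 2 to compound 3 (0.71 log units; beyond the scatter), and the last two rest on a limit. The number clearly responds to this group, but those swaps are larger changes than the one here. A small move is therefore expected, leaning towards a higher number. In this assay the estimated step is a 1.6-fold higher number from compound 3 to compound 4 (0.21 log units; within the scatter), which would not be a clear change. The estimated value for compound 4 is 20000 nM, with an expected range from 8000 nM to 50000 nM.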

Compound 4, half-maximal inhibitory concentration: 51000 nM
Estimate against measurement, compound 4: 2.6-fold (0.41 log units) below, outside the stated range (above it).
By their numbers in this assay, from the lowest: compound 3; then compounds 1 and 4 (each within the scatter of the next). At a limit, above all of these: compound 2.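

In this assay, among these compounds, the earlier steps swapped one substituted ring for a differently substituted one, whereas 2-bromophenyl and 4-bromophenyl have the same atoms and the same counts, and this swap alone gives a 4.2-fold higher number from compound 3 to compound 4 (0.62 log units; beyond the scatter). So, for this pair, the number depends on where the bromine sits on the ring and not only on which atoms the group contains, and the advantage of compound 3 does not extend to its 4-bromophenyl isomer. Of the other comparisons, a 1.9-fold higher number from compound 1 to compound 4 (0.28 log units; within the scatter), stays within the scatter, so the 4-bromophenyl and 2,4-dichlorophenyl groups cannot be separated here. The remaining one gives an at least 1.2-fold lower number from compound 2 to compound 4 (0.09 log units; that floor lies within the scatter) and rests on a limit, so it shows only a floor. Compound 2 gives only a limit and not a number: the limit of > 64000 nM in this assay, at which 1 of the 4 values shown sits.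

The compounds shown leave open how a 3-bromophenyl group would compare with the two bromine isomers, and whether 2-chlorophenyl or 2-methoxyphenyl would match the value of compound 3. They also give no explanation of why moving the bromine changes the number.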